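Removing a Methoxy Group: What the Growth Assay Might Show

This account rests on a few compounds, and the source may have more. Where it says the series, first, only, none or still open, it means among the compounds named here.

Of the compounds shown here, three have been measured in a functional assay on CAKI-1 cells (Homo sapiens) for inhibition, read by sulforhodamine B assay, with a stated time of 48 h; on this read-out lower numbers stand for stronger inhibition of growth and higher numbers for weaker inhibition of growth. Compound 1 `COc1ccc(-c2ccc(-c3ccc(C(=N)N)o3)o2)cc1` gives 1750 nM in this assay. Compound 2 `N=C(N)c1ccc(-c2ccc(-c3ccc(Cl)cc3)s2)s1` gives 1610 nM, and compound 3 `COc1cc(OC)cc(-c2ccc(-c3ccc(C(=N)N)o3)o2)c1` gives 4330 nM. Among these three numbers compound 1 stands second highest; its value and that of compound 2 sit within the usual scatter, so neither can be called stronger, whereas compound 3 gives a higher number that lies beyond the scatter.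

Compound 4 `N=C(N)c1ccc(-c2ccc(-c3ccccc3)o2)o1` differs from compound 1 in one place: hydrogen in place of methoxy on an aromatic carbon. Among the compounds with values here, no measured pair shows this change, so the expectation rests on compound 1 alone. A small step toward a lower number is expected: a 1.3-fold lower number from compound 1 to compound 4 (0.13 log units; within the scatter). Compound 4 is estimated at 1300 nM, with a range from 500 nM to 3500 nM.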

Compound 4, concentration for 50% growth inhibition: 3400 nM
For compound 4 the middle estimate is 2.6-fold (0.42 log units) below the measured one, within the range that was stated.
By their numbers in this assay, from the lowest: compounds 2, 1, 4 and 3 (each within the scatter of the next, the first and the last beyond it).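

Swapping methoxy for hydrogen on the aromatic carbon para to a large group gives a 1.9-fold higher number from compound 1 to compound 4 (0.29 log units; within the scatter) in this assay, the first direct look at this change. The methoxy group at this place is therefore not shown to matter for growth inhibition, since compound 1 and compound 4 cannot be told apart on this read-out. Nothing available explains this result.

From the compounds shown here alone, whether a hydroxyl group, an amine or a longer chain such as ethoxy at this place would move the number beyond the scatter remains open. A single pair also cannot say whether the same swap behaves alike on other cores.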